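Sulfonamide aryl variation in this assay: compound 1 to compound 4

The source may report more compounds than this note shows. Statements on the series, on what has been measured and on what is new or still open speak of the compounds shown alone.

Compound 1 `O=S(=O)(Nc1ccc(Cl)c(Cl)c1)c1ccc(-c2cnc(C3CC3)o2)cc1`: in a functional assay on cells (leukaemia cell line, Homo sapiens) for inhibition, read by sulforhodamine B assay, with a stated time of 48 h (a higher number here means a weaker inhibitor of growth, a lower number a stronger inhibitor of growth), compound 1 gives 62100 nM.
Compound 2 `Cc1ccc(NS(=O)(=O)c2ccc(-c3cnc(C4CC4)o3)cc2)cc1C`: in this assay compound 2 gives > 100000 nM, which is a limit of the assay and not a number.
Compound 3 `Cc1ccc(Cl)c(NS(=O)(=O)c2ccc(-c3cnc(C4CC4)o3)cc2)c1`: in this assay compound 3 gives 52800 nM.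

Among the two numbers shown, compound 1 has the highest; its nearest neighbour is compound 3, and the step of a 1.2-fold lower number from compound 1 to compound 3 (0.07 log units; within the scatter) lies within the scatter, so no order between the two is claimed. Compound 2 sits at the limit of > 100000 nM in this assay, at which 1 of the 3 values shown sits.

Compound 4 `Cc1cc(Cl)cc(NS(=O)(=O)c2ccc(-c3cnc(C4CC4)o3)cc2)c1` is not yet measured. It differs from compound 1 by 3-chloro-5-methylphenyl in place of 3,4-dichlorophenyl on a sulfonamide nitrogen. For the measured compounds named here, two measured steps bear on this: an at least 1.6-fold higher number from compound 1 to compound 2 (0.20 log units; that floor lies within the scatter), where both chlorines give way to methyls, and a 1.2-fold lower number from compound 1 to compound 3 (0.07 log units; within the scatter), where one chlorine and one methyl remain. Compound 4 keeps one chlorine and one methyl, so the expected step of a 1.3-fold higher number from compound 1 to compound 4 (0.11 log units; within the scatter) is small, within the scatter, leaning toward a higher number. Compound 4 is therefore expected at 80000 nM, with a range from 40000 nM to 160000 nM, and a real chance that only a limit is reported.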

Compound 4, concentration for total growth inhibition: 7040 nM
For compound 4 the middle estimate is 11-fold (1.06 log units) above the measured one, outside the stated range (below it).
By their numbers in this assay, from the lowest: compound 4; then compounds 3 and 1 (each within the scatter of the next). At a limit, above all of these: compound 2.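

With one chlorine and one methyl on each ring, 3-chloro-5-methylphenyl in place of 2-chloro-5-methylphenyl gives a 7.5-fold lower number from compound 3 to compound 4 (0.88 log units; beyond the scatter), so in this assay the arrangement of these two groups on the aryl ring at the sulfonamide nitrogen moves the number, not only which groups are present. The same group gives an 8.8-fold lower number from compound 1 to compound 4 (0.95 log units; beyond the scatter) and an at least 14-fold lower number from compound 2 to compound 4 (1.15 log units; beyond the scatter), whereas none of the steps among the three earlier compounds was shown to lie beyond the scatter. Compound 2 stands at a limit and not a number, so its step is a floor: the limit of > 100000 nM in this assay, at which 1 of the 4 values shown sits.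

The compounds shown carry only chlorine and methyl on this ring, and no reason for the step can be read from them. From the compounds shown here alone, how a methoxy group, an amine or a carboxylic acid would read at this place remains open.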